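Propyl in Place of Methyl on an Inactive Quinoline-Triazole Scaffold

This account rests on a few compounds, and the source may have more. Where it says the series, first, only, none or still open, it means among the compounds named here.

Compound 1 `Cc1cc2ccccc2nc1-c1cn(-c2ccc(F)cc2)nn1`: > 100 ug/mL
Compound 2 `CCCCCCCCCCn1cc(-c2nc3ccccc3cc2CCC)nn1`: > 100 ug/mL
Compound 3 `CCCCCc1cc2ccccc2nc1-c1cn(CCC(F)(F)C(F)(F)C(F)(F)C(F)(F)C(F)(F)C(F)(F)C(F)(F)C(F)(F)F)nn1`: > 100 ug/mL

In a functional assay on COLO 205 cells (Homo sapiens) for cytotoxicity, read by MTT assay, with a stated time of 24 h (a lower number here means a stronger inhibitor, a higher number a weaker inhibitor), compound 1 reaches only a limit, > 100 ug/mL, and no number. Compound 2 likewise gives a limit, > 100 ug/mL. Compound 3 also stops at a limit, > 100 ug/mL. All three measured values therefore sit at the same point, (the limit of > 100 ug/mL in this assay, at which 3 of the 3 values shown sit), so compound 1 stands nowhere above or below its companions; the numbers show no order among them. Compound 4 `CCCc1cc2ccccc2nc1-c1cn(-c2ccc(F)cc2)nn1` differs from compound 1 by ethyl in place of hydrogen on a saturated chain carbon bound to an aromatic carbon. Within the data shown here, no measured pair shows a step of this kind, and with every value at the limit there is no step to lean on. The author expects the step that the limit leaves unreadable from compound 1 to compound 4 to be none beyond the scatter, and estimates compound 4 at 150 ug/mL, between 60 ug/mL and 400 ug/mL, most likely again only a limit.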

Compound 4, half-maximal inhibitory concentration: > 100 ug/mL
Compound 4 ended at the assay's limit; the forecaster's own chance of this, stated with the estimate: 80%; the middle value lies beyond the limit too.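

Among these compounds, compound 1 and compound 4 both stand at the assay's limit, so no step between them can be read: the limit of > 100 ug/mL in this assay, at which 4 of the 4 values shown sit. The compounds shown leave open whether, in this assay, any change on the shared core gives a readable value.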